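Dropping the chloro from compound 2's benzamide ring

The source may report more compounds than this note shows. Statements on the series, on what has been measured and on what is new or still open speak of the compounds shown alone.

Compound 2 `O=C(Nc1ccc(-n2ccc3nc(C(=O)NCc4ccccc4)ccc32)cc1)c1ccc(Cl)c(C(F)(F)F)c1` is the reference point of this account. Among the compounds with values here, in a functional assay on A375P cells (Homo sapiens) for cytotoxicity, read by MTT assay (a lower number here means a stronger inhibitor, a higher number a weaker inhibitor), compound 2 gives 700 nM, and this is the only plain number in the set. Compound 1 `NC(=O)c1ccc2c(ccn2-c2ccc(NC(=O)c3cccc(C(F)(F)F)c3)cc2)n1` carries a primary amide where compound 2 carries a benzylamide, and it also lacks the chloro. For compound 1 the assay reports only > 10000 nM, which is a limit and not a number. Because compound 1 sits at the limit of > 10000 nM in this assay, at which 1 of the 2 values shown sits, and differs from compound 2 in two places at once, its reading says nothing definite about either change on its own.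

Compound 3 `O=C(Nc1ccc(-n2ccc3nc(C(=O)NCc4ccccc4)ccc32)cc1)c1cccc(C(F)(F)F)c1` differs from compound 2 in one place only: hydrogen in place of chloro on an aromatic carbon. Within the data shown here, no measured pair covers this change, so the expectation rests on the structures alone. The writer expects a loss of potency somewhat beyond the usual scatter, an estimated step of a 2.9-fold higher number from compound 2 to compound 3 (0.46 log units; beyond the scatter) in this assay. For compound 3 the estimated value in this assay is 2000 nM, with a likely range from 700 nM to 7000 nM.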

Compound 3, half-maximal inhibitory concentration: 3000 nM
Compound 3: middle estimate off by 1.5-fold (0.18 log units), on the low side; the measured number falls inside the stated range.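

The new value separates the two changes that were tangled together in compound 1. In this assay, taking away the chloro alone, at the place ortho to the trifluoromethyl group and para to a large group, gives a 4.3-fold higher number from compound 2 to compound 3 (0.63 log units; beyond the scatter), so the 4-chloro-3-(trifluoromethyl)phenyl and the 3-(trifluoromethyl)phenyl are not equivalent here, whereas the benzyl on the amide-type nitrogen, read with the chloro absent from both compounds, gives an at least 3.3-fold lower number from compound 1 to compound 3 (0.52 log units; beyond the scatter). That second step is only a bound and not a measured size, since compound 1 stands at a limit and not at a number: the limit of > 10000 nM in this assay, at which 1 of the 3 values shown sits.

The compounds shown do not tell whether another group at this place on the benzamide ring, such as a fluoro, a methyl or a methoxy, would keep the number of compound 2 or lose potency as hydrogen does. Nor do they tell how the benzyl on the amide nitrogen compares with a shorter or longer chain, such as a methyl or a phenethyl, or with an amine in its place.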